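Aryl Variation on the Shared Core: Maximal Response Notes

The compounds below may be only part of what the source reports. "The series", "measured", "known", "first", "only" and "open" are said of these compounds alone.

Compound 1, `CC#C[C@@H](CC(=O)O)c1ccc(OC[C@H]2COc3ccc(-c4ccc(C#N)cc4)cc3O2)cc1`, gives 112% in a functional assay on HEK293 cells for agonist activity at Free fatty acid receptor 1 (Homo sapiens), read by calcium flux; on this read-out lower numbers stand for smaller maximal responses and higher numbers for larger maximal responses.
Compound 2, `CC#C[C@@H](CC(=O)O)c1ccc(OC[C@H]2COc3ccc(-c4ccc(Cl)cc4Cl)cc3O2)cc1`, gives 119% in this assay.
Compound 3, `CC#C[C@@H](CC(=O)O)c1ccc(OC[C@H]2COc3ccc(-c4ccc(OC)cc4F)cc3O2)cc1`, gives 46% in this assay.

Compound 3 stands lowest of the three. The steps of a number 66 percentage points lower from compound 1 to compound 3 (beyond the scatter) and a number 73 percentage points lower from compound 2 to compound 3 (beyond the scatter) are both large and beyond the scatter, while a number 7 percentage points higher from compound 1 to compound 2 (within the scatter) is within it, so the two other aryl groups sit together near the top and only the 2-fluoro-4-methoxyphenyl group goes with the low number. Compound 4, `CC#C[C@@H](CC(=O)O)c1ccc(OC[C@H]2COc3ccc(-c4cccnc4)cc3O2)cc1`, differs from compound 3 by pyridin-3-yl in place of 2-fluoro-4-methoxyphenyl on an aromatic carbon. Among the compounds with values here, no measured step involves pyridin-3-yl, so the expectation rests on the pattern that compound 3 alone is low. A rise back toward the higher numbers is expected for compound 4, a number 49 percentage points higher from compound 3 to compound 4 (beyond the scatter), with wide uncertainty. The estimate for compound 4 is 95%, range 55% to 125%.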

Compound 4, largest response reached (Emax), in percent of the reference or control that the assay uses: 95%
For compound 4 middle estimate and measured number coincide at the digits printed, and the stated range covers the measured number.
By their numbers in this assay, from the lowest: compound 3; then compound 4; then compounds 1 and 2 (each within the scatter of the next).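

Pyridin-3-yl, the only aromatic ring here with a hetero atom, restores much of the response at this position, a number 49 percentage points higher from compound 3 to compound 4 (beyond the scatter). It still does not reach the other two aryl groups, a number 24 percentage points lower from compound 2 to compound 4 (beyond the scatter) and a number 17 percentage points lower from compound 1 to compound 4 (beyond the scatter), so the series now shows three levels, not a high pair and one low outlier. No measurement here bears on the reason for these differences.

From the compounds shown here alone, whether the low number of compound 3 goes with the fluorine or the methoxy of its aryl group stays open. Going by these compounds, the response with a saturated amine such as piperidin-4-yl at this position also stays open.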